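Adding a Methyl Group: One Kind of Change, Two Places

The source may report more compounds than this note shows. Statements on the series, on what has been measured and on what is new or still open speak of the compounds shown alone.

In a toxicity assay on HepG2 cells (Homo sapiens) for inhibition, read by CellTiter-Glo, with a stated time of 48 h (a higher number here means a weaker inhibitor, a lower number a stronger inhibitor), compound 1 `Cc1cc(C)cc(NC(=O)COc2cc(C)nc3ccccc23)c1` gives only a limit of the assay, > 100000 nM (the limit of > 100000 nM in this assay, at which 1 of the 3 values shown sits). Compound 2 `Cc1cc(C)cc(NC(=O)COc2cc(C)nc3ccc(C)cc23)c1` differs by methyl in place of hydrogen on an aromatic carbon and gives 15900 nM in this assay, a step of an at least 6.2-fold lower number from compound 1 to compound 2 (0.79 log units; beyond the scatter). Compound 3 `COc1ccc2nc(C)cc(OCC(=O)Nc3ccccc3)c2c1` has a different core; how its core differs from that of compound 1 is not broken down here. In this assay compound 3 gives 39800 nM.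

Compound 4 `COc1ccc2nc(C)cc(OCC(=O)Nc3cccc(C)c3)c2c1` differs from compound 3 by methyl in place of hydrogen on an aromatic carbon. This is the same kind of change as from compound 1 to compound 2, not the same: there the added group sat on a ring that is part of a fused or bridged system of two rings, meta to a fused ring and para to a fused ring, whereas here it sits on a six-membered aromatic ring of carbon only, meta to a large group. A smaller step, a 1.8-fold lower number from compound 3 to compound 4 (0.26 log units; within the scatter), is expected for compound 4 in this assay, since only compound 1 and compound 2 show this kind of change and at a different place. Compound 4 is estimated at 22000 nM, between 8000 nM and 70000 nM.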

Compound 4, half-maximal inhibitory concentration in the HepG2 assay: 39800 nM
Beside the measured number, compound 4's estimate is 1.8-fold (0.26 log units) below it, within the range that was stated.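

Within the data shown here, in the HepG2 assay the methyl group gives no change at the digits printed from compound 3 to compound 4 (within the scatter), so the step seen on the core of compound 1 did not carry over at the same size to the core of compound 3: the same change on two cores in the HepG2 assay, an at least 6.2-fold lower number (0.79 log units; beyond the scatter) from compound 1 to compound 2 and no change at the digits printed (within the scatter) from compound 3 to compound 4, at least 6.2-fold (0.79 log units) apart, beyond the scatter of two such steps In the HepG2 assay compound 1 gives > 100000 nM as a limit of the assay, so the size of the earlier step is itself open-ended: the limit of > 100000 nM in the HepG2 assay, at which 1 of the 4 values shown sits. This does not show that the core alone sets the outcome, as the methyl in compound 4 sits on a six-membered aromatic ring of carbon only, a different place from the one in compound 2, so core and place cannot be told apart here. In a physicochemical assay for solubility, in phosphate buffer, measured as kinetic solubility, with a stated time of 1 h, at pH 7.4 (a higher number here means a more soluble compound, a lower number a less soluble compound), compound 3 gives 63000 nM and compound 4 gives 193000 nM as measured, so the methyl group comes with a higher solubility: the measured solubility of compound 3, 63000 nM, and of compound 4, 193000 nM, a 3.1-fold higher number (0.49 log units; beyond the scatter)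

The compounds shown hold no pair with the methyl added at the same place on both cores. Going by these compounds, how an ethyl group or an amine would act at this place on compound 3 also stays open.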